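Phenyl in place of isopropyl on the urea nitrogen

A few compounds are considered here, and "the series" means these few. Any claim that something is new, unique, unknown or untested is made for them only; others in the source may bear on it.

Working notes on the shared core. Compound 1 `CC(C)NC(=O)NC1CC(C)(C)Oc2ccc(Cl)cc21` gives no number of its own: in a functional assay on T98G cells (Homo sapiens) for inhibition, read by MTT assay, with a stated time of 72 h (a higher number here means a weaker inhibitor, a lower number a stronger inhibitor), compound 1 gives > 100000 nM, which is a limit of the assay rather than a measured value. Among the three results shown, compound 1 is the one that sits at this limit, as noted in the limit of > 100000 nM in this assay, at which 1 of the 3 values shown sits.

Compound 2 `CC1(C)CC(NC(=O)Nc2ccc(Cl)cc2)c2cc(Br)ccc2O1` carries an aryl group on the urea nitrogen and gives 27000 nM in this assay. Compound 3 `CC1(C)CC(NC(=S)Nc2cccc(C#N)c2)c2cc(Cl)ccc2O1` is a thiourea with an aryl group on the corresponding nitrogen and gives 10000 nM in this assay. Going by the values given here, no pair of measured compounds differs in a single place, so these values can be set beside one another but no single step can be read from them.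

Compound 4 `CC1(C)CC(NC(=O)Nc2ccccc2)c2cc(Cl)ccc2O1` differs from compound 1 in one place: phenyl in place of isopropyl on an amide-type nitrogen. Both compounds that carry an aryl group on that nitrogen, compound 2 and compound 3, report numbers rather than a limit, so a move toward stronger inhibition is expected for compound 4, of uncertain size. The expected step is an at least 3.3-fold lower number from compound 1 to compound 4 (0.52 log units; beyond the scatter). Compound 4 is estimated at 30000 nM, with a range from 8000 nM to 100000 nM.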

Compound 4, half-maximal inhibitory concentration: 34000 nM
For compound 4 the middle estimate is 1.1-fold (0.05 log units) below the measured one, within the range that was stated.
By their numbers in this assay, from the lowest: compound 3; then compounds 2 and 4 (each within the scatter of the next). At a limit, above all of these: compound 1.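

In this assay, going by these compounds alone, phenyl in place of isopropyl on an amide-type nitrogen gives an at least 2.9-fold lower number from compound 1 to compound 4 (0.46 log units; beyond the scatter) as the first step that can be read from a single change. Until now an aryl group on this nitrogen and a numerical result appeared together only in compound 2 and compound 3, which also differ from compound 1 elsewhere; compound 4 keeps the rest of compound 1 and carries a phenyl with no further substituent, so this one change is enough to bring the result from a limit to a number. The step has a lower bound and no upper bound because the value of compound 1 is a limit: the limit of > 100000 nM in this assay, at which 1 of the 4 values shown sits.

The phenyl brings both a ring and more heavy atoms, so these compounds do not show which of the two goes with the lower number; a cyclohexyl or a benzyl group on the same nitrogen would separate them. On these data alone, the effect of single substituents on the phenyl, such as a methoxy group or a carboxylic acid, also stays open, as compound 2 and compound 3 each differ from compound 4 in more than one place.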